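Swapping thiophen-3-yl for 2-fluorophenyl on a shared core

A few compounds are considered here, and "the series" means these few. Any claim that something is new, unique, unknown or untested is made for them only; others in the source may bear on it.

Measured so far:
compound 1 (`NC(=O)[C@@H]1[C@H](Nc2nc(Nc3cccc(C(=O)N4CCCC4)c3)ncc2C2CC2)[C@H]2C=C[C@@H]1C2`): 90 nM
compound 2 (`NC(=O)[C@@H]1[C@H](Nc2nc(Nc3cccc(C(=O)N4CCCC4)c3)ncc2-c2ccsc2)[C@H]2C=C[C@@H]1C2`): 110 nM

Among the compounds with values here, in a functional assay on THP-1 cells (Homo sapiens) for inhibition, read by ELISA, with stated times of 1 h and 18 h (a higher number here means a weaker inhibitor, a lower number a stronger inhibitor), compound 2 gives 110 nM and so lies within the scatter of compound 1, the only other compound measured. Compound 3 (`NC(=O)[C@@H]1[C@H](Nc2nc(Nc3cccc(C(=O)N4CCCC4)c3)ncc2-c2ccccc2F)[C@H]2C=C[C@@H]1C2`) keeps the shared core and carries 2-fluorophenyl in place of thiophen-3-yl on an aromatic carbon. Within the data shown here, only one measured step bears on that carbon, thiophen-3-yl in place of cyclopropyl (a 1.2-fold higher number from compound 1 to compound 2 (0.09 log units; within the scatter)), and it stayed within the scatter, so no step beyond the scatter is expected in this assay for compound 3, in either direction. Among the measured compounds shown here, no measured compound carries 2-fluorophenyl there, so the range is kept wide. The estimated step is small (a 1.1-fold lower number from compound 2 to compound 3 (0.04 log units; within the scatter)). Compound 3 is estimated at 100 nM (range 40 nM to 260 nM).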

Compound 3, half-maximal inhibitory concentration: 130 nM
Estimate against measurement, compound 3: 1.3-fold (0.11 log units) below; low and high end bracket the measured number.
By their numbers in this assay, from the lowest: compounds 1, 2 and 3 (each within the scatter of the next).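

In this assay, the 2-fluorophenyl group stays within the scatter of both earlier groups on this aromatic carbon, whether set against thiophen-3-yl (a 1.2-fold higher number from compound 2 to compound 3 (0.07 log units; within the scatter)) or cyclopropyl (a 1.4-fold higher number from compound 1 to compound 3 (0.16 log units; within the scatter)). The position thus accepts a six-membered aromatic ring of carbon only, with 7 heavy atoms and no hydrogen-bond acceptor, in place of a five-membered aromatic ring with 5 heavy atoms and 1 hydrogen-bond acceptor, with no step beyond the scatter among the three compounds. No supporting evidence accompanies these numbers to account for this result. The compounds shown leave open whether any group on this carbon would move the number beyond the scatter, for example an amine, a carboxylic acid or a longer chain. They also leave open what the fluorine contributes, since unsubstituted phenyl does not appear among them.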